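This account rests on a few compounds, and the source may have more. Where it says the series, first, only, none or still open, it means among the compounds named here.

Measured so far in a functional assay on MCF7 cells (Homo sapiens) for inhibition, read by MTT assay, with a stated time of 72 h; a higher number here means a weaker inhibitor, a lower number a stronger inhibitor:
- Compound 1 `Nc1nc2cc(-c3nn(CCCCCCCCCC(=O)NO)c4ncnc(N)c34)ccc2o1`: > 50000 nM (a limit)
- Compound 2 `Nc1nc2cc(-c3nn(CC(=O)NO)c4ncnc(N)c34)ccc2o1`: > 100000 nM (a limit)

Compound 2 gives no number, only the limit > 100000 nM. Compound 1 likewise gives only a limit, > 50000 nM. These two results cannot be ranked against each other, and neither gives a measured potency to build on.

Compound 3 `Nc1nc2cc(-c3nn(CCCCCCC(=O)NO)c4ncnc(N)c34)ccc2o1` keeps the shared core and the hydroxycarbamoyl end group of compound 2 but carries it on a longer chain: 5-(hydroxycarbamoyl)pentyl in place of hydroxycarbamoyl on a saturated chain carbon bound to an aromatic nitrogen. Here 5-(hydroxycarbamoyl)pentyl stands in place of hydroxycarbamoyl on a saturated chain carbon bound to an aromatic nitrogen. The resulting chain is longer than that of compound 2 and shorter than that of compound 1, a length not yet tested in this assay.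

A clear move towards stronger inhibition is expected, with the estimated change being an at least 20-fold lower number from compound 2 to compound 3 (1.30 log units; beyond the scatter). That expectation is uncertain: compound 1, with the longer chain, shows only the limit > 50000 nM, so added length alone does not assure a measurable effect. The estimate for compound 3 is 5000 nM, with an expected range from 500 nM to 40000 nM.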

Compound 3, half-maximal inhibitory concentration: 11900 nM
Compound 3: the middle estimate sits 2.4-fold (0.38 log units) below what was measured; the range from low to high includes it.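

In this assay, replacing hydroxycarbamoyl with 5-(hydroxycarbamoyl)pentyl on the saturated chain carbon bound to an aromatic nitrogen gives an at least 8.4-fold lower number from compound 2 to compound 3 (0.92 log units; beyond the scatter), so chain length at this position can turn a compound with no measured potency into one with a real number. The longer chain of compound 1 offers no further gain, as shortening it to the chain of compound 3 gives an at least 4.2-fold lower number from compound 1 to compound 3 (0.62 log units; beyond the scatter), which places the only measured value at the intermediate length among the three chains shown. Both steps are minimum sizes, not exact ones, as each starts from a limit rather than a number, and the limit for compound 2 sets the first of them: the limit of > 100000 nM in this assay, at which 1 of the 3 values shown sits.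

The compounds shown leave open how sharply the effect depends on length, which other chains, such as 3-(hydroxycarbamoyl)propyl, could help to settle. They also leave open whether the hydroxycarbamoyl end group itself matters, which a carboxylic acid in its place on the chain of compound 3 could test.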